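The source may hold more compounds than are shown below. What is called first, only, known or untested is meant among the compounds shown, and "the series" means these compounds.

In a functional assay on K562 cells (Homo sapiens) for antiproliferative activity, with a stated time of 72 h (a higher number here means a weaker inhibitor, a lower number a stronger inhibitor), compound 1 `CCCCC#Cc1cc([C@@H]2O[C@H](CO)[C@@H](O)[C@H]2O)n2ncnc(N)c12` gives 2400 nM. Compound 2 `Nc1ncnn2c([C@@H]3O[C@H](CO)[C@@H](O)[C@H]3O)cc(C#Cc3ccc(F)cc3)c12` gives > 100000 nM, which is a limit of the assay and not a number. Compound 2 therefore has no exact position on the scale. The comparison between them is an at least 41-fold higher number from compound 1 to compound 2 (1.61 log units; beyond the scatter), a large step beyond the scatter made by placing 4-fluorophenyl in place of butyl on a triple-bonded carbon.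

Compound 3 `Nc1ncnn2c([C@@H]3O[C@H](CO)[C@@H](O)[C@H]3O)cc(C#Cc3ccccc3)c12` follows from compound 2 through (hydrogen in place of fluoro on an aromatic carbon), with hydrogen in place of fluoro on an aromatic carbon. For the measured compounds named here, no measured step covers this swap. Compound 3 keeps an aromatic ring on the triple-bonded carbon, so the large loss seen in an at least 41-fold higher number from compound 1 to compound 2 (1.61 log units; beyond the scatter) is expected to persist in this assay, with at most a modest move toward a lower number.

Compound 3 is estimated at 50000 nM, with an expected range from 10000 nM to 100000 nM. The estimated change is an at least 2.0-fold lower number from compound 2 to compound 3 (0.30 log units; that floor lies within the scatter).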

Compound 3, half-maximal inhibitory concentration: > 100000 nM
Compound 3: no number, only a limit (the forecaster's own chance of this, stated with the estimate: 55%); middle value at least 2.0-fold (0.30 log units) from the limit.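

In this assay compound 3 gives > 100000 nM, a limit of the assay and not a number. Phenyl in place of butyl on the triple-bonded carbon gives an at least 41-fold higher number from compound 1 to compound 3 (1.61 log units; beyond the scatter), so the large loss seen with 4-fluorophenyl also appears without the fluoro on the ring. The change from fluoro to hydrogen itself cannot be read, and any effect of it on the aromatic carbon stays hidden: the limit of > 100000 nM in this assay, at which 2 of the 3 values shown sit.

Butyl is the only group on the triple-bonded carbon here that gives a readable value, so it remains open whether that value depends on the chain as such or on its length. A longer chain, such as hexyl, or a butyl chain ending in an amine or a hydroxyl group could separate these possibilities, and a cyclohexyl ring could show whether the loss extends to rings that are not aromatic.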